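The source may report more compounds than this note shows. Statements on the series, on what has been measured and on what is new or still open speak of the compounds shown alone.

Compounds measured so far:
- compound 1, `O=C(CN1CN(c2ccccc2)C2(CCN(C(=O)c3ccc(C4CCCCC4)cc3)CC2)C1=O)NCCO`: 2000 nM
- compound 2, `CC(C)(C)c1ccc(C(=O)N2CCC3(CC2)C(=O)N(CC(=O)N2CCCC(CO)C2)CN3c2ccccc2)cc1`: 8200 nM
- compound 3, `CS(=O)(=O)N1CCN(C(=O)CN2CN(c3ccccc3)C3(CCN(C(=O)c4ccc(C5CCCCC5)cc4)CC3)C2=O)CC1`: 6300 nM

These three share a core and differ only in the group attached to the carbonyl carbon at the end of the chain. In an assay on HEK293 cells for displacement of a labelled ligand from NPC1-like intracellular cholesterol transporter 1 (Homo sapiens) (on this read-out higher numbers stand for weaker inhibition and lower numbers for stronger inhibition), compound 1 gives 2000 nM, while compound 3 gives 6300 nM and compound 2 gives 8200 nM. Compound 2 carries the highest number of the three: its gap to compound 3 is within the scatter, so no order between those two can be read, but its gap to compound 1 is beyond the scatter.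

Compound 4, `CC(C)(C)c1ccc(C(=O)N2CCC3(CC2)C(=O)N(CC(=O)N2CCCC(C(N)=O)C2)CN3c2ccccc2)cc1`, is compound 2 with one alteration: carbamoyl in place of hydroxymethyl on a saturated ring carbon. Within the data shown here, no measured pair shows this exact exchange. Among the measured compounds shown here, the only step among the measured compounds, a 3.2-fold higher number from compound 1 to compound 3 (0.50 log units; beyond the scatter), concerns a different exchange at the same carbonyl carbon and offers no direct guide to swapping hydroxymethyl for carbamoyl. In such a case the smallest assumption is that the number stays close to that of compound 2, and the step of a 1.0-fold lower number from compound 2 to compound 4 (0.01 log units; within the scatter) is therefore expected to lie within the scatter. Compound 4 is estimated at 8000 nM in this assay, with a range from 3000 nM to 25000 nM.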

Compound 4, half-maximal inhibitory concentration: 16900 nM
Beside the measured number, compound 4's estimate is 2.1-fold (0.32 log units) below it; low and high end bracket the measured number.
By their numbers in this assay, from the lowest: compound 1; then compounds 3 and 2 (each within the scatter of the next); then compound 4.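

In this assay, carbamoyl in place of hydroxymethyl on a saturated ring carbon gives a 2.1-fold higher number from compound 2 to compound 4 (0.31 log units; beyond the scatter), a modest weakening of inhibition but one that can be read. Among these compounds, this is the first sign that this ring carbon, two ring bonds from the ring nitrogen, is not indifferent to what it carries: the two groups have the same count of hydrogen-bond donors and acceptors and neither has a net charge, yet the number still moves, so small edits far out on the chain can register in this assay. Nothing available gives a reason for the shift.

On these data alone, it remains open whether a carboxylic acid, a primary amine or a longer chain at this ring carbon would lower the number or raise it further, and whether the bare piperidin-1-yl ring would sit closer to compound 2 or to compound 4. Also open, as far as these compounds go, is whether the same exchange would have a similar effect in a compound carrying the cyclohexyl group of compound 1 instead of the tert-butyl group of compound 2.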